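Swapping a small heterocycle for a larger one

The source may hold more compounds than are shown below. What is called first, only, known or untested is meant among the compounds shown, and "the series" means these compounds.

Compound 1 `FC(F)(F)c1ccccc1OC1CCN(c2ccc(-c3nnco3)nn2)CC1` carries a 1,3,4-oxadiazol-2-yl ring on the shared core. In an assay on microsomes from liver for inhibition of acyl-CoA desaturase 1 (Rattus norvegicus) (on this read-out higher numbers stand for weaker inhibition and lower numbers for stronger inhibition), compound 1 gives 22 nM, the second highest of the three numbers: compound 3 `c1cc2c(c(OC3CCN(c4ccc(-n5ccnc5)nn4)CC3)c1)CCC2` gives 10 nM, and compound 2 `N#Cc1ccccc1OC1CCN(c2ccc(-n3ccnc3)nn2)CC1` gives 236 nM. Among the compounds with values here, the only step between two measured compounds that differ in one place, a 24-fold lower number from compound 2 to compound 3 (1.37 log units; beyond the scatter), concerns the group on the oxygen, not the heterocycle. Compound 4 `CC(C)Cc1nnc(-c2ccc(N3CCC(Oc4ccccc4C(F)(F)F)CC3)nn2)s1` differs from compound 1 in one place: 5-isobutyl-1,3,4-thiadiazol-2-yl in place of 1,3,4-oxadiazol-2-yl on an aromatic carbon. Within the data shown here, no measured step touches this part of the core, so neither the direction nor the size of the change can be read from the data, and the expectation rests on compound 1 alone. The estimate for compound 4 is 15 nM, within 4 nM to 60 nM, which means an expected 1.5-fold lower number from compound 1 to compound 4 (0.17 log units; within the scatter).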

Compound 4, half-maximal inhibitory concentration: 37 nM
Compound 4: the middle estimate sits 2.5-fold (0.39 log units) below what was measured; the measured number falls inside the stated range.
By their numbers in this assay, from the lowest: compound 3; then compounds 1 and 4 (each within the scatter of the next); then compound 2.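

In this assay, within the data shown here, 5-isobutyl-1,3,4-thiadiazol-2-yl in place of 1,3,4-oxadiazol-2-yl gives a 1.7-fold higher number from compound 1 to compound 4 (0.23 log units; within the scatter), the first measured step at this position. The position therefore accepts a group of 9 heavy atoms instead of 5 with no change that stands out from the scatter. Nothing measured here gives a reason for this result.

Going by these compounds, the ring sulfur and the isobutyl chain enter together, so their separate contributions stay open. Also open, on these data alone, is how a longer chain, an amine or a carboxylic acid on this ring would read.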